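Aryl variation on the fused core, agonist potency

The source may hold more compounds than are shown below. What is called first, only, known or untested is meant among the compounds shown, and "the series" means these compounds.

Measured compounds:
compound 1 `CC#CC(CC(=O)O)c1ccc(OCc2ccc3nc(-c4ccc(C5CCCCC5)cc4)cn3c2)cc1`, 417 nM
compound 2 `CC#CC(CC(=O)O)c1ccc(OCc2ccn3cc(-c4cccc(C)c4)nc3c2)cc1`, 1510 nM
compound 3 `CC#CC(CC(=O)O)c1ccc(OCc2ccc3nc(-c4ccc(F)cc4)cn3c2)cc1`, 623 nM

In an assay on isolated protein for agonist activity at Free fatty acid receptor 1 (Homo sapiens) (a higher number here means that more compound is needed for the effect, a lower number that less compound is needed), compound 2 gives the highest of the three numbers; compound 3 sits nearest, and compound 1 furthest, both beyond the scatter. Compound 4 `CC#CC(CC(=O)O)c1ccc(OCc2ccn3cc(-c4cc(F)ccc4F)nc3c2)cc1` is not yet measured. The change from compound 2 to compound 4 is 2,5-difluorophenyl in place of 3-methylphenyl on an aromatic carbon.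

Among the measured compounds shown here, only one measured step bears on this: a 1.5-fold higher number from compound 1 to compound 3 (0.17 log units; within the scatter). That step, on the core of compound 1, swaps a large hydrocarbon ring for a single fluorine without moving the number beyond the scatter. For the measured compounds named here, no measured pair on the core of compound 2 varies the aryl group, so the size of the present step is open. Given that compound 3 with its fluorophenyl gives 623 nM, and that the only comparable step was within the scatter, a small step toward a lower number is expected, a 1.5-fold lower number from compound 2 to compound 4 (0.18 log units; within the scatter), without confidence that it clears the scatter. Compound 4 is therefore estimated at 1000 nM, with a range from 400 nM to 2500 nM.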

Compound 4, half-maximal effective concentration: 639 nM
Compound 4: the middle estimate sits 1.6-fold (0.19 log units) above what was measured, within the range that was stated.
By their numbers in this assay, from the lowest: compounds 1, 3 and 4 (each within the scatter of the next); then compound 2.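

On the core of compound 2, the aryl group on an aromatic carbon of the five-membered aromatic ring now has a measured step in this assay: 2,5-difluorophenyl in place of 3-methylphenyl gives a 2.4-fold lower number from compound 2 to compound 4 (0.37 log units; beyond the scatter) and so shows that a change of aryl substituents at this position can clear the scatter. Among the compounds shown here, the only earlier step, a 1.5-fold higher number from compound 1 to compound 3 (0.17 log units; within the scatter) on the other core, did not, although it exchanged a far larger group. Nothing on hand accounts for the new step.

For the compounds shown here, the two fluorines and the removal of the methyl remain inseparable here, as no compound on this core carries a single fluorine or an unsubstituted phenyl. As far as these compounds go, it also remains open how this position responds to a methoxy group, a nitrile or an amine on the phenyl ring.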